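Extending a Methylsulfanyl Dithiocarbamate by One Carbon

The source may report more compounds than this note shows. Statements on the series, on what has been measured and on what is new or still open speak of the compounds shown alone.

Compound 2 `CSC(=S)N[C@H]1CCOC1=O` is the smaller of two measured compounds. In a functional assay on MGC-803 cells (Homo sapiens) for cytotoxicity, read by MTT assay, with a stated time of 72 h (a higher number here means a weaker inhibitor, a lower number a stronger inhibitor), compound 2 reaches only a limit, > 128000 nM. That value sits at the limit of > 128000 nM in this assay, at which 1 of the 2 values shown sits. Compound 1 `Cc1cccc(NC(=O)CSC(=S)N[C@H]2CCOC2=O)c1` gives 36600 nM in this assay. The unmeasured compound 3 `CCSC(=S)N[C@H]1CCOC1=O` differs from compound 2 by methyl in place of hydrogen on a saturated chain carbon bound to a sulfur. Going by the values given here, with no measured step of this kind, the expected step that the limit leaves unreadable from compound 2 to compound 3 is none beyond the scatter. Compound 3 is therefore estimated at 140000 nM, within 60000 nM to 300000 nM.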

Compound 3, half-maximal inhibitory concentration: > 128000 nM
Compound 3: no number, only a limit; the forecaster's own chance of this, stated with the estimate: 75%; the middle value is on the limit's open side.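

Going by these compounds alone, compound 3, like compound 2, reaches only a limit of the assay, and no step between them can be read. The compounds shown leave open whether methyl in place of hydrogen on this saturated chain carbon changes anything in this assay.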